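Trading the 1-aminoethyl for methyl on a weak series

This account rests on a few compounds, and the source may have more. Where it says the series, first, only, none or still open, it means among the compounds named here.

Compound 1 `COc1cc(NC(C)CCCN2C(=O)[C@H](C)NC2(C)C)c2ncccc2c1` and compound 2 `COc1cc(NC(C)CCCN2C(=O)CN(C(=O)[C@H](C)N)C2(C)C)c2ncccc2c1` share a core and differ in the ring-bound amide portion. In a functional assay on HT-29 cells (Homo sapiens) for antiproliferative activity, read by sulforhodamine B assay, with a stated time of 48 h (on this read-out lower numbers stand for stronger inhibition and higher numbers for weaker inhibition), compound 1 returns only a limit, > 100000 nM. In this assay, going by the values given here, compound 2 gives 46300 nM, the single number reported here. The remaining entry sits at the limit of > 100000 nM in this assay, at which 1 of the 2 values shown sits. Compound 3 `COc1cc(NC(C)CCCN2C(=O)CN(C(C)=O)C2(C)C)c2ncccc2c1` has not yet been measured. It differs from compound 2 by methyl in place of 1-aminoethyl on a carbonyl carbon, so the (1-aminoethyl)carbonyl becomes acetyl. Among the compounds with values here, no measured step of this kind is available, and compound 2 already sits near the top of the measured range. Compound 3 is expected to drift toward weaker inhibition in this assay, with the estimated step of a 1.7-fold higher number from compound 2 to compound 3 (0.24 log units; within the scatter), though a result within the scatter would not surprise. The estimate for compound 3 is 80000 nM, ranging from 30000 nM to 300000 nM.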

Compound 3, half-maximal inhibitory concentration: > 100000 nM
Compound 3: a limit, no number; the forecaster's own chance of this, stated with the estimate: 50%; middle value at least 1.2-fold (0.09 log units) away from the limit.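

In this assay, methyl in place of 1-aminoethyl on a carbonyl carbon gives an at least 2.1-fold higher number from compound 2 to compound 3 (0.33 log units; beyond the scatter), so the acetyl compound loses the measurable, though weak, inhibition seen with the (1-aminoethyl)carbonyl group. Compound 3 gives > 100000 nM, which is a limit and not a number. The true size of the step therefore stays unknown, since the read-out ends at this limit for most of the compounds shown: the limit of > 100000 nM in this assay, at which 2 of the 3 values shown sit.

The amine and the extra carbon leave together in this change, so the compounds shown do not tell which of them accounts for the step. Going by these compounds, whether an aminomethyl or a 1-hydroxyethyl group on the same carbonyl carbon would hold the value of compound 2, or improve on it, remains open.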